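Swapping methyl for chloro on compound 1

A few compounds are considered here, and "the series" means these few. Any claim that something is new, unique, unknown or untested is made for them only; others in the source may bear on it.

compound 1 `Cc1ccc(NC(=S)SCC2=CCOC2=O)cc1` gives 97400 nM
compound 2 `O=C1OCC=C1CSC(=S)NC1CCCCC1` gives 180000 nM

Both values come from a functional assay on MCF7 cells (Homo sapiens) for antiproliferative activity, read by MTT assay, with a stated time of 72 h (a higher number here means a weaker inhibitor, a lower number a stronger inhibitor), and lie within the usual scatter of each other. Compound 1 therefore stands level with compound 2 and the two cannot be ranked.

Still unmeasured is compound 3 `O=C1OCC=C1CSC(=S)Nc1ccc(Cl)cc1` which differs from compound 1 in one place. The change is chloro in place of methyl on an aromatic carbon and in words it is chloro in place of methyl on an aromatic carbon, para to a large group.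

For the measured compounds named here, no measured pair shows this swap directly. Compound 2 differs from compound 1 in a much larger part of the structure, yet compound 2 reads 180000 nM and stays within the scatter of compound 1 at 97400 nM in the same measurement. On that basis, no step beyond the scatter is expected in this assay in either direction. The expected step is a 1.2-fold lower number from compound 1 to compound 3 (0.09 log units; within the scatter) and this stays within the scatter. Compound 3 is expected at 80000 nM with a likely range from 35000 nM to 180000 nM as an estimate.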

Compound 3, half-maximal inhibitory concentration: "not active" (no number reported)
For compound 3 the study gives words and no number; no gap can be computed for the estimate.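

In this assay, for the compounds shown here, compound 3 is described only in words, as "not active", with no number, so no step from compound 1 to compound 3 can be read. No measurement shown here bears on this result. On these data alone, how far chloro in place of methyl shifts the number for compound 1 therefore remains open.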